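Replacing chloro with hydrogen in compound 1

The source may hold more compounds than are shown below. What is called first, only, known or untested is meant among the compounds shown, and "the series" means these compounds.

- compound 1 `O=C(Nc1nnc(-c2cccc(O)c2O)s1)c1ccc(Cl)cc1`: 13000 nM
- compound 2 `Cc1ccc(C(=O)Nc2nnc(-c3ccc(O)c(O)c3)s2)cc1`: 67100 nM

Going by the values given here, in a functional assay on HeLa cells (Homo sapiens) for cytotoxicity, read by MTT assay, with a stated time of 72 h (a higher number here means a weaker inhibitor, a lower number a stronger inhibitor), compound 1 (13000 nM) holds the lower of the two numbers so far. Compound 2 (67100 nM) stands higher, and the gap between the two lies beyond the scatter. The two measured compounds differ in more than one place, so they offer no direct measure of any single change.

Compound 3 `O=C(Nc1nnc(-c2cccc(O)c2O)s1)c1ccccc1` has not yet been measured. It departs from compound 1 by one change (hydrogen in place of chloro on an aromatic carbon), with hydrogen in place of chloro on an aromatic carbon, para to a large group, which turns 4-chlorophenyl into phenyl. Among the compounds with values here, compound 1 (13000 nM) is the lower of only two numbers, so a new compound seems more likely to fall above it than below it. A modest step toward a higher number, just beyond the scatter, is therefore expected in this assay (a 2.3-fold higher number from compound 1 to compound 3 (0.36 log units; beyond the scatter)). Compound 3 is estimated at 30000 nM (expected range 10000 nM to 80000 nM).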

Compound 3, half-maximal inhibitory concentration: 21800 nM
Compound 3: middle estimate off by 1.4-fold (0.14 log units), on the high side; measured number inside the range.
By their numbers in this assay, from the lowest: compounds 1 and 3 (each within the scatter of the next); then compound 2.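

In this assay, going by these compounds alone, putting hydrogen in place of chloro on an aromatic carbon, para to a large group, gives a 1.7-fold higher number from compound 1 to compound 3 (0.22 log units; within the scatter), the first single change that can be read in this set. On this one pair, then, going from 4-chlorophenyl to phenyl does not move the number beyond the scatter, and the chloro shows no measurable contribution to the cytotoxic effect seen here. No measurement shown here accounts for this result.

Going by these compounds, whether a different group at this position, such as a methoxy group, an amine or a carboxylic acid, would shift the number beyond the scatter remains open, since this single pair compares only chloro with hydrogen. Within the data shown here, compound 2 differs from compound 1 and from compound 3 in more than one place, so no step to it can be read, and what any single feature of compound 2 contributes remains unknown.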